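A few compounds are considered here, and "the series" means these few. Any claim that something is new, unique, unknown or untested is made for them only; others in the source may bear on it.

Three measured compounds share one core and differ only in the substituted phenyl group attached to it. Compound 1 `CC(=O)NCc1ccc(-c2ccc(COC3CC[C@H](N4CCCCCC4)[C@H]3OC/C=C\CCC(=O)O)cc2)cc1` carries a 4-(acetamidomethyl)phenyl group; compound 2 `O=C(O)CC/C=C\CO[C@H]1[C@@H](OCc2ccc(-c3ccc(CO)cc3)cc2)CC[C@@H]1N1CCCCCC1` and compound 3 `CS(=O)(=O)Nc1ccccc1-c1ccc(CO[C@H]2CC[C@H](N3CCCCCC3)[C@H]2OC/C=C\CCC(=O)O)cc1` carry other substituted phenyl groups. In a functional assay for antagonist activity at thromboxane A2 receptor (Rattus norvegicus) (a higher number here means weaker binding, a lower number tighter binding), compound 1 gives 20 nM, the lowest number of the three. Compound 2 gives 50.1 nM, and compound 3 gives 63.1 nM. Only one step among these compounds can be followed directly: the exchange of one substituted phenyl for another, which moved the number by a 1.3-fold higher number from compound 2 to compound 3 (0.10 log units; within the scatter).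

Compound 4 `NC(=O)c1ccccc1-c1ccc(COC2CC[C@H](N3CCCCCC3)[C@H]2OC/C=C\CCC(=O)O)cc1` makes a comparable exchange starting from compound 1: 2-carbamoylphenyl in place of 4-(acetamidomethyl)phenyl on an aromatic carbon. Within the data shown here, because the one comparable step, a 1.3-fold higher number from compound 2 to compound 3 (0.10 log units; within the scatter), stayed within the scatter, a small step is expected here too, perhaps a slight weakening, estimated as a 1.8-fold higher number from compound 1 to compound 4 (0.24 log units; within the scatter). Compound 4 is therefore expected to give about 35 nM in this assay, with a likely range from 12 nM to 100 nM.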

Compound 4, dissociation constant: 15.9 nM
Beside the measured number, compound 4's estimate is 2.2-fold (0.34 log units) above it; measured number inside the range.
By their numbers in this assay, from the lowest: compounds 4 and 1 (each within the scatter of the next); then compounds 2 and 3 (each within the scatter of the next).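

In this assay the exchange of 4-(acetamidomethyl)phenyl for 2-carbamoylphenyl gives a 1.3-fold lower number from compound 1 to compound 4 (0.10 log units; within the scatter) and so leaves the number unchanged within the scatter, even though the entering group has fewer heavy atoms and its amide stands on a different ring position. Among these compounds, this is the second exchange of one substituted phenyl for another at this place, para to a large group, and the first that starts from compound 1, the best-placed of the earlier compounds; like the step from compound 2 to compound 3, it stays within the scatter. Nothing available explains why these two groups give such similar numbers. On these data alone, whether the same holds for a carboxylic acid or a simple amine at this place stays open. So does the effect of a longer chain between the ring and the amide.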